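A methyl on the acid chain of compound 1

The compounds below may be only part of what the source reports. "The series", "measured", "known", "first", "only" and "open" are said of these compounds alone.

In an ADME assay on cells (Hepatocyte, Homo sapiens) for metabolic stability, read by LC-MS, with a stated time of 180 min, tested at 1 uM (a higher number here means faster removal of the compound, a lower number slower removal), compound 1 `O=C(O)Cn1nc(Cn2cc3cc(OCC4CC4)c(Cl)cc3n2)c2ccccc2c1=O` gives only a limit, < 11.7 mL/min/kg. Compound 2 `O=C(O)Cc1nn(Cc2cn3cc(OCC4CC4)c(Cl)cc3n2)c2ccccc2c1=O` also gives only a limit, < 6.67 mL/min/kg. Compound 3 `CC(C)(C(=O)O)c1nn(Cc2cn3cc(OCC4CC4)c(Cl)cc3n2)c2ccccc2c1=O` likewise gives a limit, < 10 mL/min/kg. Compound 1 therefore stands among three limits and cannot be ranked. Compound 4 `C[C@H](C(=O)O)n1nc(Cn2cc3cc(OCC4CC4)c(Cl)cc3n2)c2ccccc2c1=O` differs from it by methyl in place of hydrogen on a saturated chain carbon bound to an aromatic nitrogen and a carbonyl carbon, which also reads as carboxymethyl to 1-carboxyethyl. Within the data shown here, the only measured step that bears on this is a step that the two limits leave unreadable from compound 2 to compound 3, on a core other than that of compound 1, and it gives no size to carry over. In this assay the expected change is a step that the limit leaves unreadable from compound 1 to compound 4, estimated to stay within the scatter, with no direction expected. For compound 4 the estimated clearance is 7 mL/min/kg, with an expected range of 3 mL/min/kg to 14 mL/min/kg.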

Compound 4, clearance: < 10 mL/min/kg
Compound 4 ended at the assay's limit; the forecaster's own chance of this, stated with the estimate: 75%; the middle value is on the limit's open side.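

In this assay, among these compounds, compound 1 and compound 4 both give only limits, so no step between them can be read. The compounds shown leave open whether methyl in place of hydrogen changes clearance at all.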